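Removing the hydroxy group on the side chain

The compounds below may be only part of what the source reports. "The series", "measured", "known", "first", "only" and "open" are said of these compounds alone.

Compound 3 `CN1CCN(c2nc3ccccc3n2CCO)CC1` gives 410 nM in a functional assay on ileum for inhibition of histamine H1 receptor (Cavia porcellus) (on this read-out lower numbers stand for stronger inhibition and higher numbers for weaker inhibition), the second highest of the three numbers. Compound 1 `COCCCn1c(N2CCN(C)CC2)nc2ccccc21` gives 860 nM and compound 2 `CCCCOCCn1c(N2CCN(C)CC2)nc2ccccc21` gives 38 nM; the step of a 2.1-fold lower number from compound 1 to compound 3 (0.32 log units; beyond the scatter) is modest, while an 11-fold higher number from compound 2 to compound 3 (1.03 log units; beyond the scatter) is large. Compound 4 `CCCn1c(N2CCN(C)CC2)nc2ccccc21` differs from compound 3 by methyl in place of hydroxy on a saturated chain carbon, two bonds along the chain from an aromatic nitrogen. Among the compounds with values here, no measured step is this exact change, but the large step of an 11-fold higher number from compound 2 to compound 3 (1.03 log units; beyond the scatter), hydrogen in place of butyl on the oxygen, read the other way is a large gain on replacing the hydroxy with a butoxy, which suggests that a chain without the hydroxy is tolerated. Compound 4 is therefore expected to show a moderately lower number, a 2.7-fold lower number from compound 3 to compound 4 (0.44 log units; beyond the scatter). The estimate for compound 4 is 150 nM, with a range from 40 nM to 600 nM.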

Compound 4, half-maximal inhibitory concentration: 380 nM
Estimate against measurement, compound 4: 2.5-fold (0.40 log units) below, and the stated range covers the measured number.
By their numbers in this assay, from the lowest: compound 2; then compounds 4 and 3 (each within the scatter of the next); then compound 1.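

Methyl in place of hydroxy on the saturated chain carbon gives, in this assay, a 1.1-fold lower number from compound 3 to compound 4 (0.03 log units; within the scatter), so the hydroxy and the methyl cannot be told apart at this position. Methyl in place of butoxy at the same carbon gives a 10-fold higher number from compound 2 to compound 4 (1.00 log units; beyond the scatter), which ties the low number of compound 2 to the butoxy rather than to the mere absence of the hydroxy. Hydrogen in place of methoxy, three bonds along the chain from an aromatic nitrogen, gives a 2.3-fold lower number from compound 1 to compound 4 (0.35 log units; beyond the scatter).

Going by these compounds, whether a shorter ether such as ethoxy, a longer chain than butoxy or an amine at this position would keep the number of compound 2 remains open. No evidence at hand speaks to what lies behind these steps.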